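The compounds below may be only part of what the source reports. "The series", "measured", "known", "first", "only" and "open" are said of these compounds alone.

Working notes on the series.

Among the measured compounds shown here, compound 1 `COC(=O)CN(C)c1nc(Nc2cccc(OC)c2)ncc1[N+](=O)[O-]` and compound 2 `CCOC(=O)CN(Cc1ccccc1)c1nc(Nc2ccc(Cl)cc2)ncc1[N+](=O)[O-]` share a core and differ at two places, the ester, the substituent on the non-ring nitrogen, and the aryl group on the ring nitrogen, so no single-point step links them. In a functional assay on MCF7 cells (Homo sapiens) for antiproliferative activity, read by MTT assay, with a stated time of 48 h (on this read-out higher numbers stand for weaker inhibition and lower numbers for stronger inhibition), compound 1 gives 93700 nM. For compound 2 in this assay only a limit is recorded, > 100000 nM, which is a limit of the assay and not a number; this is the situation described by the limit of > 100000 nM in this assay, at which 1 of the 2 values shown sits. Compound 2 therefore stands at the weak end of what the numbers shown can express.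

Compound 3 `CCOC(=O)CN(Cc1ccccc1)c1nc(NCc2ccccc2)ncc1[N+](=O)[O-]` has not been measured. Its difference from compound 2 is benzyl in place of 4-chlorophenyl on a nitrogen on an aromatic ring. For the measured compounds named here, no measured step between compounds that differ in one place is available, so the expected size of the step rests on the position of compound 2 alone. Given that compound 2 already sits at the limit, the step is expected to be a step that the limit leaves unreadable from compound 2 to compound 3, that is, no movement beyond the scatter is anticipated in either direction. For compound 3 the expected value in this assay is 130000 nM, with a range from 40000 nM to 400000 nM, and a further limit rather than a number is the likelier outcome.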

Compound 3, half-maximal inhibitory concentration: > 100000 nM
Compound 3: no number, only a limit (the forecaster's own chance of this, stated with the estimate: 65%); the middle value is on the limit's open side.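

In this assay compound 3 gives > 100000 nM, a limit of the assay and not a number. Compound 2 also carries a limit, so no step can be read from compound 2 to compound 3: the limit of > 100000 nM in this assay, at which 2 of the 3 values shown sit.

The compounds shown leave open whether benzyl in place of 4-chlorophenyl on this nitrogen changes antiproliferative activity at all.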